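This account rests on a few compounds, and the source may have more. Where it says the series, first, only, none or still open, it means among the compounds named here.

Within the data shown here, in a functional assay on DU-145 cells (Homo sapiens) for inhibition (on this read-out lower numbers stand for stronger inhibition of growth and higher numbers for weaker inhibition of growth), compound 2 `O=S(=O)(/C=C/c1ccc(Br)cc1)Cc1ccc(Nc2ncnc3ccc(Br)cc23)cc1` gives 3000 nM, the lower of the two numbers so far, and compound 1 `O=S(=O)(/C=C/c1ccc(Cl)c(Cl)c1)Cc1ccc(Nc2ncnc3ccc(Br)cc23)cc1` gives 17000 nM. Compound 3 `O=S(=O)(/C=C/c1ccc(Cl)cc1)Cc1ccc(Nc2ncnc3ccc(Br)cc23)cc1` differs from compound 2 by one swap: chloro in place of bromo on an aromatic carbon, para to a large group. Among the measured compounds shown here, the only measured step that bears on this is modest, a 5.7-fold lower number from compound 1 to compound 2 (0.75 log units; beyond the scatter), and it changes the ring by more than this one swap, so it guides only loosely. The expected change is small, a 1.5-fold higher number from compound 2 to compound 3 (0.18 log units; within the scatter), leaning slightly toward a higher number. Compound 3 is expected at 4500 nM, with an estimated range of 1500 nM to 14000 nM.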

Compound 3, concentration for 50% growth inhibition: 1000 nM
Beside the measured number, compound 3's estimate is 4.5-fold (0.65 log units) above it; the measured number lies below the stated range.
By their numbers in this assay, from the lowest: compound 3; then compound 2; then compound 1.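

In this assay, the exchange of a single atom on this ring, chloro in place of bromo, gives a 3.0-fold lower number from compound 2 to compound 3 (0.48 log units; beyond the scatter) and so moves the number beyond the scatter. Replacing one chloro of the 3,4-dichlorophenyl group with hydrogen gives a 17-fold lower number from compound 1 to compound 3 (1.23 log units; beyond the scatter) and makes 4-chlorophenyl the group with the lowest number of the three. No measurement here explains either step. Going by these compounds, whether fluoro, methoxy or an amine at this place, para to a large group, would lower the number further remains open.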